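Aryl versus benzyl amines on a shared chloropyrimidine core

A few compounds are considered here, and "the series" means these few. Any claim that something is new, unique, unknown or untested is made for them only; others in the source may bear on it.

Compound 1 `Cc1ccccc1Nc1nc(Nc2ccccn2)ncc1Cl`: 11200 nM
Compound 2 `Cc1ccccc1Nc1nc(Nc2ccc(N3CCNCC3)cn2)ncc1Cl`: 5060 nM
Compound 3 `CN1CCN(c2ccc(Nc3ncc(Cl)c(NCc4ccccc4)n3)nc2)CC1`: 24800 nM

In a functional assay on MDA-MB-231 cells (Homo sapiens) for inhibition, read by CCK-8 assay, with a stated time of 48 h (a lower number here means a stronger inhibitor of growth, a higher number a weaker inhibitor of growth), compound 3 gives the highest number of the three, and it is the weakest inhibitor of growth among the measured compounds. Within the data shown here, the only single step that is measured is a 2.2-fold lower number from compound 1 to compound 2 (0.35 log units; beyond the scatter), which shows that the piperazin-1-yl group on the pyridyl side lowers the number modestly.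

Compound 4 `CC(C)c1ccccc1Nc1nc(Nc2ccc(N3CCN(C)CC3)cn2)ncc1Cl` is made from compound 3 by the change (2-isopropylphenyl in place of benzyl on a nitrogen on an aromatic ring). Among the measured compounds shown here, no measured step matches this change directly: the gap between compound 3 and compound 2 involves two differences at once, so only their two values can be compared, and compound 2 carries an aryl amine with a lower value than that of compound 3. Since compound 4 carries an aryl amine as compound 2 does, and retains a piperazinyl group like the one whose effect is seen in a 2.2-fold lower number from compound 1 to compound 2 (0.35 log units; beyond the scatter), the number for compound 4 is expected to fall toward the range of compound 2, a downward step estimated as a 5.5-fold lower number from compound 3 to compound 4 (0.74 log units; beyond the scatter). Compound 4 is therefore estimated at 4500 nM, within 1500 nM to 13000 nM.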

Compound 4, concentration for 50% growth inhibition: 4090 nM
Compound 4: the middle estimate sits 1.1-fold (0.04 log units) above what was measured, and the stated range covers the measured number.
By their numbers in this assay, from the lowest: compounds 4 and 2 (each within the scatter of the next); then compound 1; then compound 3.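

Among these compounds, this result gives the first measured single step at the amine position of the shared core: in this assay, with everything else held constant, putting 2-isopropylphenyl in place of benzyl on the nitrogen gives a 6.1-fold lower number from compound 3 to compound 4 (0.78 log units; beyond the scatter). Until now, the benzyl and aryl amines could be set against each other only through compound 3 and compound 2, which differ in more than one place, so the contribution of this position could not be separated from that of the other changes. The step now shows that this position alone moves the growth-inhibition number beyond the scatter, and no measurement is available that explains why it does so. The change from benzylamino to (2-isopropylphenyl)amino both removes the carbon between the ring and the nitrogen and adds an isopropyl group, and the compounds shown do not separate these two parts. As far as these compounds go, it also remains open how a plain phenyl group, or a phenyl ring carrying a methoxy group or a carboxylic acid, would behave on this nitrogen with the rest of compound 4 kept the same.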